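Microsomal half-life across the aryl-alkoxy tail

The compounds below may be only part of what the source reports. "The series", "measured", "known", "first", "only" and "open" are said of these compounds alone.

Three analogues of one shared core have been run in an ADME assay on microsomes from liver (Rattus norvegicus) for metabolic stability, read by LC-MS, tested at 0.5 uM; a higher number here means that the compound lasts longer, a lower number that the compound disappears faster. Compound 1 `COc1cccc(CCOc2ccc(-c3c(C)nc(C)c([C@H](OC(C)(C)C)C(=O)O)c3N3CCC(C)(C)CC3)cc2)c1` carries a 3-methoxyphenyl on a saturated chain carbon, two bonds along the chain from an oxygen on an aromatic ring. In this assay compound 1 gives > 2 h, which is a limit of the assay and not a number. Compound 2 `Cc1cc(CCOc2ccc(-c3c(C)nc(C)c([C@H](OC(C)(C)C)C(=O)O)c3N3CCC(C)(C)CC3)cc2)ccc1F` gives > 2 h in this assay, again a limit. Compound 3 `Cc1nc(C)c([C@H](OC(C)(C)C)C(=O)O)c(N2CCC(C)(C)CC2)c1-c1ccc(OCCCc2ccc(F)cc2)cc1` gives > 2 h in this assay, also a limit. The three steps between them are therefore not readable: a step that the two limits leave unreadable from compound 1 to compound 2, a step that the two limits leave unreadable from compound 1 to compound 3 and a step that the two limits leave unreadable from compound 2 to compound 3. Compound 3 thus stands only at a limit, as do the two other values shown, and the whole picture rests on (the limit of > 2 h in this assay, at which 3 of the 3 values shown sit).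

Compound 4 `Cc1nc(C)c([C@H](OC(C)(C)C)C(=O)O)c(N2CCC(C)(C)CC2)c1-c1ccc(OCCc2cccnc2)cc1` differs from compound 3 by pyridin-3-yl in place of 4-fluorobenzyl on a saturated chain carbon, two bonds along the chain from an oxygen on an aromatic ring. Among the compounds with values here, none of the measured steps can be read for size, so no direction is taken from them; the change to compound 4 sits at the same place on the tail as the earlier ones, all of which reach the limit (the limit of > 2 h in this assay, at which 3 of the 3 values shown sit). Compound 4 is expected to give a half-life in this assay of about 2 h, within a range from 1 h to 4 h. The step from compound 3 to compound 4 is accordingly estimated as a number no higher from compound 3 to compound 4 (the limit leaves the size open).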

Compound 4, half-life: 0.783 h
The estimate for compound 4 lay 2.6-fold (0.41 log units) above the measured number, outside the stated range (below it).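

Within the data shown here, at this position, the change to pyridin-3-yl gives the first readable steps on the tail in this assay: an at least 2.5-fold lower number from compound 3 to compound 4 (0.40 log units; beyond the scatter), an at least 2.5-fold lower number from compound 2 to compound 4 (0.40 log units; beyond the scatter) and an at least 2.5-fold lower number from compound 1 to compound 4 (0.40 log units; beyond the scatter). The earlier compounds shown here could not show that the group on a saturated chain carbon, two bonds along the chain from an oxygen on an aromatic ring, makes any difference to half-life, whereas compound 4 shows that it can. Compound 1 and compound 2 share the chain of compound 4, so the fall goes with the pyridin-3-yl ring and does not depend on the shorter chain that separates compound 4 from compound 3. The steps among the first three compounds cannot be read, and the true size of the new steps stays open: the limit of > 2 h in this assay, at which 3 of the 4 values shown sit.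

The compounds shown leave open whether the fall belongs to the ring nitrogen as such or to its place in the ring, a question that pyridin-2-yl and pyridin-4-yl on the same chain would address. They also leave open how an unsubstituted phenyl or a pyrimidine ring would sit against compound 4, and whether a longer chain carrying pyridin-3-yl would behave the same way.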